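The compounds below may be only part of what the source reports. "The series", "measured", "known", "first", "only" and "open" are said of these compounds alone.

Measured in an assay on isolated protein with dual specificity calcium/calmodulin-dependent 3',5'-cyclic nucleotide phosphodiesterase 1B (Bos taurus) as the target, tested at 100 uM; on this read-out lower numbers stand for less inhibition and higher numbers for more inhibition at the one concentration tested (going by the name of the read-out):
compound 1 `Cn1c(N)nc2c1c(=O)n(CC1CC1)c(=O)n2CC1CC1` — 30%
compound 2 `COc1ccc(Cn2c(N)nc3c2c(=O)n(CC2CC2)c(=O)n3CC2CC2)cc1` — 60%
compound 3 `Cc1ccc(S(=O)(=O)n2c(N)nc3c2c(=O)n(CC2CC2)c(=O)n3CC2CC2)cc1` — 9%

Compound 3 stands lowest of the three in this assay; the nearest number is that of compound 1, the furthest that of compound 2. The two steps that end at compound 3 are a number 21 percentage points lower from compound 1 to compound 3 (beyond the scatter) and a number 51 percentage points lower from compound 2 to compound 3 (beyond the scatter), and both come from replacing the group on the aromatic nitrogen as a whole.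

Compound 4 `Nc1nc2c(c(=O)n(CC3CC3)c(=O)n2CC2CC2)n1S(=O)(=O)c1ccc([N+](=O)[O-])cc1` keeps that (4-methylphenyl)sulfonyl framework and changes only its far end: nitro in place of methyl on an aromatic carbon, para to a large group. For the measured compounds named here, none of the measured steps touches this position; all three vary the aromatic nitrogen itself, so there is no direct precedent for the size of such a change in this assay. With compound 3 already near the bottom of the range seen, the expectation is a step of about a number 3 percentage points higher from compound 3 to compound 4 (within the scatter), that is, nothing clearly beyond the scatter, in either direction. Compound 4 is therefore estimated at 12% in this assay, with a range from 0% to 30%.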

Compound 4, a percentage reported as inhibition, at one concentration (the size of the read-out at that concentration, not a potency): 14%
For compound 4 the middle estimate is 2 percentage points below the measured one; the range from low to high includes it.
By their numbers in this assay, from the lowest: compounds 3 and 4 (each within the scatter of the next); then compound 1; then compound 2.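

In this assay, for the compounds shown here, this is the first change at the far end of the sulfonyl-bound ring: nitro in place of methyl on an aromatic carbon gives a number 5 percentage points higher from compound 3 to compound 4 (within the scatter). At this position, then, going from 4-methylphenyl to 4-nitrophenyl does not separate the two compounds, and the number stays at the low end of the series with either group. Nothing available bears on why this exchange leaves the number within the scatter.

Going by these compounds, it remains open whether an amine, a carboxylic acid or a methoxy group on the same aromatic carbon would also leave the number unchanged. Also open, on these data alone, is whether a carbonyl in place of the sulfonyl, with the 4-nitrophenyl kept, would give a different number.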